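A few compounds are considered here, and "the series" means these few. Any claim that something is new, unique, unknown or untested is made for them only; others in the source may bear on it.

Compound 1 `COc1ccc(C(OCc2ccccc2)c2cccc3ccccc23)c(OC)c1OC`: in a functional assay on MDA-MB-231 cells (Homo sapiens) for inhibition, read by sulforhodamine B assay, with a stated time of 48 h (on this read-out lower numbers stand for stronger inhibition and higher numbers for weaker inhibition), compound 1 gives > 20000 nM
Compound 2 `COc1ccc(C(OCc2ccc(C)cc2)c2cccc3ccccc23)c(OC)c1OC`: in this assay compound 2 gives > 20000 nM

Both entries sit at the limit of > 20000 nM in this assay, at which 2 of the 2 values shown sit. The value of compound 1 is a limit of the assay, not a number. The value of compound 2 is likewise a limit. The step that the two limits leave unreadable from compound 1 to compound 2 therefore has no readable size. Compound 3 `COc1ccc(C(c2ccc(OCC(=O)O)cc2)c2cccc3ccccc23)c(OC)c1OC` differs from compound 2 by 4-(carboxymethoxy)phenyl in place of (4-methylbenzyl)oxy on a saturated chain carbon bound to two aromatic carbons. No measured step bears on this change, and the single step shown gives no size to lean on. The expected step is a step that the limit leaves unreadable from compound 2 to compound 3, of no readable size. Compound 3 is estimated at 25000 nM (range 8000 nM to 80000 nM), most likely reported again only as a limit.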

Compound 3, half-maximal inhibitory concentration: > 20000 nM
Compound 3: a limit, no number; the forecaster's own chance of this, stated with the estimate: 70%; the middle value is on the limit's open side.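

No step can be read from compound 2 to compound 3 or from compound 1 to compound 3, because all these values are limits, not numbers: the limit of > 20000 nM in this assay, at which 3 of the 3 values shown sit.
The compounds shown leave open whether any change to the shared core gives a readable number in this assay at all.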